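Swapping the thiourea substituent: from sulfonamide to chlorobenzyl

The source may report more compounds than this note shows. Statements on the series, on what has been measured and on what is new or still open speak of the compounds shown alone.

Measured compounds:
- compound 1 `CCc1cccc(Nc2ncnc3ccc(NC(=S)NCc4ccccc4)cc23)c1`: 10500 nM
- compound 2 `CC(C)(C)c1ccc(Nc2ncnc3ccc(NC(=S)NCc4ccccc4)cc23)cc1`: 8700 nM
- compound 3 `NS(=O)(=O)c1ccc(NC(=S)Nc2ccc3ncnc(Nc4cccc(Br)c4)c3c2)cc1`: > 30000 nM

In a functional assay on MDA-MB-231 cells (Homo sapiens) for inhibition, read by MTT assay, with a stated time of 48 h (a lower number here means a stronger inhibitor of growth, a higher number a weaker inhibitor of growth), compound 1 gives 10500 nM and compound 2 gives 8700 nM; the step of a 1.2-fold lower number from compound 1 to compound 2 (0.08 log units; within the scatter) changes only the aniline part and leaves the benzyl thiourea untouched. Compound 3 is different: in this assay it gives only a limit, > 30000 nM, so it stands at the limit of > 30000 nM in this assay, at which 1 of the 3 values shown sits, and no number is known for it.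

Compound 4 `S=C(NCc1ccc(Cl)cc1)Nc1ccc2ncnc(Nc3cccc(Br)c3)c2c1` keeps the core and the bromophenyl amine of compound 3 but alters the thiourea end: 4-chlorobenzyl in place of 4-sulfamoylphenyl on an amide-type nitrogen. For the measured compounds named here, no measured step changes this position, so the only guide is that compounds 1 and 2, which also carry a benzyl-type group on the thiourea nitrogen, gave numbers rather than limits. Compound 4 is therefore expected to give 10000 nM, in the range 3000 nM to 30000 nM. Relative to the limit of compound 3 this is an estimated step of an at least 3.0-fold lower number from compound 3 to compound 4 (0.47 log units; beyond the scatter), though a further limit cannot be ruled out.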

Compound 4, concentration for 50% growth inhibition: 23000 nM
Compound 4: the middle estimate sits 2.3-fold (0.36 log units) below what was measured, within the range that was stated.
By their numbers in this assay, from the lowest: compounds 2 and 1 (each within the scatter of the next); then compound 4. At a limit, above all of these: compound 3.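

In this assay compound 4, with 4-chlorobenzyl on the thiourea nitrogen, gives a real number, 23000 nM, and so this position can carry a group that gives a readable value alongside the bromophenyl amine. Compound 3, with 4-sulfamoylphenyl at that place, has only a limit, > 30000 nM. The step is an at least 1.3-fold lower number from compound 3 to compound 4 (0.11 log units; that floor lies within the scatter), and it does not establish a true gain in growth inhibition because one end of it is a limit and not a number: the limit of > 30000 nM in this assay, at which 1 of the 4 values shown sits.

The change swaps the sulfamoyl group for chlorine and a phenyl for a benzyl in one move, so the part each plays stays unresolved. Also open, on these data alone, is how an amine or a carboxylic acid in place of that chlorine, or a longer chain in place of the benzyl group, would read at this position.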